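Plasma half-life estimate for a nitrooxyethyl ester analogue

The compounds below may be only part of what the source reports. "The series", "measured", "known", "first", "only" and "open" are said of these compounds alone.

compound 1 `CC(=O)Oc1ccccc1C(=O)O[C@H]1CO[C@H]2[C@@H]1OC[C@H]2OC(C)=O`: 0.0608 h
compound 2 `CC(=O)Oc1ccccc1C(=O)O[C@H]1CO[C@H]2[C@@H]1OC[C@H]2OC(=O)c1ccc([N+](=O)[O-])cc1`: 0.0462 h
compound 3 `CC(=O)Oc1ccccc1C(=O)O[C@H]1CO[C@H]2[C@@H]1OC[C@H]2OC(=O)c1ccc(C#N)cc1`: 0.0888 h

These three compounds were tested in an ADME assay on a cell-free system (plasma, Homo sapiens) for metabolic stability, with Plasma (Rattus norvegicus) as the target, read by HPLC, at pH 7.4; on this read-out lower numbers stand for a shorter-lived compound and higher numbers for a longer-lived compound. Compound 3 gives the highest of the three numbers, yet its steps to the others, a 1.5-fold higher number from compound 1 to compound 3 (0.16 log units; within the scatter) and a 1.9-fold higher number from compound 2 to compound 3 (0.28 log units; within the scatter), both lie within the scatter, so none of the three can be called longer-lived than another. Compound 4 `CC(=O)Oc1ccccc1C(=O)O[C@H]1CO[C@H]2[C@@H]1OC[C@H]2OC(=O)CCO[N+](=O)[O-]` has not yet been measured. It differs from compound 3 in one place: 2-(nitrooxy)ethyl in place of 4-cyanophenyl on a carbonyl carbon. Among the measured compounds shown here, none of the measured steps makes this exact change; the closest comparison, methyl in place of 4-cyanophenyl, is the reverse of a 1.5-fold higher number from compound 1 to compound 3 (0.16 log units; within the scatter), which stayed within the scatter. Compound 4 is therefore expected to show a 1.5-fold lower number from compound 3 to compound 4 (0.17 log units; within the scatter), a step no larger than the scatter. The estimated value for compound 4 is 0.06 h, between 0.03 h and 0.12 h.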

Compound 4, half-life: 0.065 h
Compound 4: the middle estimate sits 1.1-fold (0.03 log units) below what was measured; the range from low to high includes it.
By their numbers in this assay, from the lowest: compounds 2, 1, 4 and 3 (each within the scatter of the next).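

In this assay, an open 2-(nitrooxy)ethyl chain with no ring can replace either aromatic group on this carbonyl carbon and the number stays within the scatter (a 1.4-fold lower number from compound 3 to compound 4 (0.14 log units; within the scatter)) and (a 1.4-fold higher number from compound 2 to compound 4 (0.15 log units; within the scatter)). Putting (nitrooxy)methyl in place of a hydrogen on the methyl group of compound 1 also stays within the scatter (a 1.1-fold higher number from compound 1 to compound 4 (0.03 log units; within the scatter)). Nothing available explains why these changes leave the half-life so little altered. Still open, as far as these compounds go, is whether an amine, a carboxylic acid or a longer chain on this carbonyl carbon would give a step beyond the scatter.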